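This account rests on a few compounds, and the source may have more. Where it says the series, first, only, none or still open, it means among the compounds named here.

Of the compounds shown here, three have been measured in an assay on isolated protein for inhibition of DNA nucleotidylexotransferase (Homo sapiens), read by scintillation counting, with a stated time of 10 min; a lower number here means a stronger inhibitor, a higher number a weaker inhibitor. Compound 1 `CCOC(=O)C(=O)CC(=O)/C=C/c1cn(Cc2ccccc2)c2ccccc12` reports only a limit in this assay, > 40 uM, not a number. Compound 2 `CC(C)CCn1cc(/C=C/C(=O)CC(=O)C(=O)O)c2ccccc21` gives 16.3 uM in this assay, and compound 3 `C=C(C)Cn1cc(/C=C/C(=O)CC(=O)C(=O)O)c2ccccc21` gives 2.5 uM. Compound 3 therefore stands with the lowest of the two numbers shown; the step of a 6.5-fold lower number from compound 2 to compound 3 (0.81 log units; beyond the scatter) is beyond the scatter, and the one further value is the limit of compound 1 (the limit of > 40 uM in this assay, at which 1 of the 3 values shown sits).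

Compound 4 `O=C(/C=C/c1cn(Cc2ccccc2)c2ccccc12)CC(=O)C(=O)O` differs from compound 3 by phenyl in place of 1-methylethenyl on a saturated chain carbon bound to an aromatic nitrogen. Within the data shown here, the only measured step at this position, a 6.5-fold lower number from compound 2 to compound 3 (0.81 log units; beyond the scatter), shows that swapping one chain group for another at the same place can move the number by a modest amount. Among the measured compounds shown here, no measured step exchanges a chain group for a ring, so the direction for compound 4 is uncertain.

Compound 4 is therefore expected to give 6 uM in this assay, within 1.5 uM to 25 uM. This estimate means a step of a 2.4-fold higher number from compound 3 to compound 4 (0.38 log units; beyond the scatter) from compound 3, a modest weakening that is expected rather than known.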

Compound 4, concentration for 50% inhibition: 7.9 uM
Beside the measured number, compound 4's estimate is 1.3-fold (0.12 log units) below it; measured number inside the range.
By their numbers in this assay, from the lowest: compound 3; then compound 4; then compound 2. At a limit, above all of these: compound 1.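

A ring can sit at this place, on a saturated chain carbon bound to an aromatic nitrogen, and still give a measurable number in this assay: the step up is a 3.2-fold higher number from compound 3 to compound 4 (0.50 log units; beyond the scatter), while the step down is a 2.1-fold lower number from compound 2 to compound 4 (0.31 log units; beyond the scatter). Benzyl therefore falls between 2-methylprop-2-en-1-yl and the isobutyl-bearing chain of compound 2, so a ring at this place does not by itself set the number. Among these compounds, compound 4 also gives a first reading at a second place, hydrogen in place of ethyl on an oxygen next to a carbonyl group, with an at least 5.0-fold lower number from compound 1 to compound 4 (0.70 log units; beyond the scatter), and this step rests on a limit rather than a number: the limit of > 40 uM in this assay, at which 1 of the 4 values shown sits.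

As far as these compounds go, whether a chlorine atom on the phenyl ring would move the number remains open. So does the effect of an amine or a longer chain at this place.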